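Oxan-4-yl on the aromatic nitrogen of compound 2

A few compounds are considered here, and "the series" means these few. Any claim that something is new, unique, unknown or untested is made for them only; others in the source may bear on it.

In a functional assay on BT-474 cells (Homo sapiens) for inhibition, read by MTT assay, with a stated time of 5 days (on this read-out lower numbers stand for stronger inhibition and higher numbers for weaker inhibition), compound 2 `Cc1cc(Nc2nc(NCc3ccc(F)cc3F)nc3[nH]ncc23)n[nH]1` gives 3220 nM, the lowest of three numbers, against compound 1 `Cc1cc(Nc2nc(NCc3ccccc3Cl)nc3[nH]ncc23)n[nH]1` at 7160 nM and compound 3 `COc1ccc(CNc2nc(Nc3cc(C)[nH]n3)c3cn[nH]c3n2)cc1` at 8230 nM. Compound 4 `Cc1cc(Nc2nc(NCc3ccc(F)cc3F)nc3c2cnn3C2CCOCC2)n[nH]1` differs from compound 2 at one place: oxan-4-yl in place of hydrogen on an aromatic nitrogen. The measured steps all change the phenyl group on the chain: a 2.2-fold lower number from compound 1 to compound 2 (0.35 log units; beyond the scatter), a 2.6-fold higher number from compound 2 to compound 3 (0.41 log units; beyond the scatter) and a 1.1-fold higher number from compound 1 to compound 3 (0.06 log units; within the scatter). None touches that nitrogen, so they give a scale of modest size and no direction. A modest move to lower numbers in this assay is expected, held loosely, as a 2.1-fold lower number from compound 2 to compound 4 (0.33 log units; beyond the scatter). The estimate for compound 4 is 1500 nM, with an expected range of 300 nM to 7000 nM.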

Compound 4, half-maximal inhibitory concentration: 2350 nM
Beside the measured number, compound 4's estimate is 1.6-fold (0.19 log units) below it; the measured number falls inside the stated range.
By their numbers in this assay, from the lowest: compounds 4 and 2 (each within the scatter of the next); then compounds 1 and 3 (each within the scatter of the next).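

Within the data shown here, the step of a 1.4-fold lower number from compound 2 to compound 4 (0.14 log units; within the scatter) in this assay is the first reading at the aromatic nitrogen, as the earlier steps all changed the phenyl group on the chain. It shows that this nitrogen accepts oxan-4-yl in place of hydrogen with no change beyond the scatter, so the hydrogen there is not required for a number in this range. Nothing available bears on why the number holds with this group.

The compounds shown leave open how a methyl group, or a piperidin-4-yl group with its ring amine, would read on this nitrogen. They also leave open whether oxan-4-yl reads the same alongside the 2-chlorophenyl of compound 1 or the 4-methoxyphenyl of compound 3.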